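Chlorophenyl in Place of Difluorophenyl on the Saturated Ring

The compounds below may be only part of what the source reports. "The series", "measured", "known", "first", "only" and "open" are said of these compounds alone.

Measured so far:
compound 1 `COc1ccc(-n2nc(Sc3ccc(Cl)cc3)cc(CC[C@@H](C)NC(=O)[C@H]3CNC[C@@H]3c3ccccc3F)c2=O)cc1` gives 160 nM
compound 2 `COc1ccc(-n2nc(Sc3ccc(Cl)cc3)cc(CC[C@@H](C)NC(=O)[C@H]3CNC[C@@H]3c3ccc(F)cc3F)c2=O)cc1` gives 60 nM

For the measured compounds named here, in an assay on CHO cells for binding affinity to Melanocortin receptor 4 (Homo sapiens) (a lower number here means a stronger inhibitor, a higher number a weaker inhibitor), compound 2 holds the lowest of the two numbers; the only measured step, a 2.7-fold lower number from compound 1 to compound 2 (0.43 log units; beyond the scatter), came from a fluoro in place of hydrogen on an aromatic carbon. Compound 3 `COc1ccc(-n2nc(Sc3ccc(Cl)cc3)cc(CC[C@@H](C)NC(=O)[C@H]3CNC[C@@H]3c3ccc(Cl)cc3)c2=O)cc1` differs from compound 2 by 4-chlorophenyl in place of 2,4-difluorophenyl on a saturated ring carbon. Going by the values given here, no measured step covers such a swap; the one step shows only that a change on this aromatic ring moved the number modestly. A small shift, if any, is therefore expected. Compound 3 is expected to give about 80 nM, between 30 nM and 250 nM. That estimate amounts to a 1.3-fold higher number from compound 2 to compound 3 (0.12 log units; within the scatter), expected to stay within the scatter.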

Compound 3, half-maximal inhibitory concentration: 45 nM
Compound 3: the middle estimate sits 1.8-fold (0.25 log units) above what was measured; measured number inside the range.
By their numbers in this assay, from the lowest: compounds 3 and 2 (each within the scatter of the next); then compound 1.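

In this assay, a swap of the whole aromatic group on this saturated ring carbon is tolerated: 4-chlorophenyl in place of 2,4-difluorophenyl gives a 1.3-fold lower number from compound 2 to compound 3 (0.12 log units; within the scatter), so neither fluorine is needed to keep this affinity. Set against 2-fluorophenyl, the same 4-chlorophenyl group gives a 3.6-fold lower number from compound 1 to compound 3 (0.55 log units; beyond the scatter), a step beyond the scatter. Nothing measured here explains either step.

Going by these compounds, what remains open is whether an unsubstituted phenyl ring would hold the number, and whether a methyl or methoxy group could replace the chlorine.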